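Removing a Hydroxy Group from an Adenosine Receptor Ligand

The source may report more compounds than this note shows. Statements on the series, on what has been measured and on what is new or still open speak of the compounds shown alone.

Of the compounds shown here, three built on a shared core have been tested in an assay on CHO cells for displacement of a labelled ligand from adenosine receptor A3 (Homo sapiens), read by scintillation counting, with a stated time of 3 h; a higher number here means a weaker inhibitor, a lower number a stronger inhibitor. Compound 1 `CCn1c(-c2ccccc2)nc2c(NC3CCCCC3)ncnc21` gives 707 nM. Compound 2 `Cn1c(-c2ccc(O)cc2)nc2c(NC3CCCC3)ncnc21`, which carries a 4-hydroxyphenyl group, gives 521 nM, the lowest number of the three, though its gap to compound 1 lies within the scatter, so the two cannot be ranked against each other. Compound 3 `CCn1c(-c2ccccc2)nc2c(N)ncnc21` gives 5780 nM, the highest of the three; the step of an 8.2-fold higher number from compound 1 to compound 3 (0.91 log units; beyond the scatter) shows that putting hydrogen in place of cyclohexyl on a nitrogen on an aromatic ring weakens binding by a modest amount.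

Compound 4 `Cn1c(-c2ccccc2)nc2c(NC3CCCC3)ncnc21` differs from compound 2 by hydrogen in place of hydroxy on an aromatic carbon; cut one bond further out, the change reads 4-hydroxyphenyl to phenyl. Among the measured compounds shown here, none of the measured steps touches this position: the only single-point step, from compound 1 to compound 3, concerns the substituent on the ring nitrogen. Compound 1 already carries a plain phenyl group and sits within the scatter of compound 2, but it also differs from compound 2 in two other places, so it offers only weak guidance. The expected step is therefore a 1.2-fold higher number from compound 2 to compound 4 (0.06 log units; within the scatter), that is, no change beyond the scatter. Compound 4 is estimated at 600 nM, with a range from 250 nM to 1500 nM.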

Compound 4, inhibition constant: 846 nM
Compound 4: the middle estimate sits 1.4-fold (0.15 log units) below what was measured, and the stated range covers the measured number.
By their numbers in this assay, from the lowest: compounds 2, 1 and 4 (each within the scatter of the next); then compound 3.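

The exchange of hydroxy for hydrogen on the aromatic carbon para to a large group now has a direct reading: in this assay the step is a 1.6-fold higher number from compound 2 to compound 4 (0.21 log units; within the scatter), with nothing else in the structure altered. The 4-hydroxyphenyl and phenyl versions of this compound pair therefore cannot be told apart, so removing the hydroxy group, with its one hydrogen-bond donor and one hydrogen-bond acceptor, makes no difference that this assay can resolve. No separate measurement is available to help explain this result.

As far as these compounds go, it remains open whether an amine, a methoxy group or a carboxylic acid in place of the hydroxy group would shift the number beyond the usual scatter, since a single exchange says little about other groups at that carbon. Among the compounds shown here, it is also open whether the same exchange would read the same way on a compound carrying the ethyl and cyclohexyl groups of compound 1, as the only pair that isolates this change shares the methyl and cyclopentyl groups of compound 2 and compound 4.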